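A few compounds are considered here, and "the series" means these few. Any claim that something is new, unique, unknown or untested is made for them only; others in the source may bear on it.

Measured so far in an assay on HEK cells for inhibition of Tryptophan 2,3-dioxygenase (Homo sapiens); on this read-out higher numbers stand for weaker inhibition and lower numbers for stronger inhibition:
- compound 1 `O=C(Nc1ccc(Cl)cc1)C(=O)N1CCC(c2ccnc3ccc(F)cc23)CC1`: 6900 nM
- compound 2 `O=C(Nc1ccc(Cl)cc1F)C(=O)N1CCC(c2ccnc3ccc(F)cc23)CC1`: 6700 nM

Among the measured compounds shown here, compound 1 and compound 2 sit within the scatter of each other; the single measured step, a 1.0-fold lower number from compound 1 to compound 2 (0.01 log units; within the scatter), concerns fluoro on an aromatic carbon and offers no guide to a change on the saturated ring. Compound 3 `O=C(Nc1ccc(Cl)cc1)C(=O)N1CC[C@@H](c2ccnc3ccc(F)cc23)[C@@H](O)C1` differs from compound 1 by hydroxy in place of hydrogen on a saturated ring carbon. For the measured compounds named here, no measured step bears on such a change, so nothing beyond the scatter is expected, though the uncertainty is wide. Compound 3 is estimated at 7000 nM (range 2500 nM to 20000 nM), meaning an expected step of a 1.0-fold higher number from compound 1 to compound 3 (0.01 log units; within the scatter).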

Compound 3, half-maximal inhibitory concentration: 37000 nM
Beside the measured number, compound 3's estimate is 5.3-fold (0.72 log units) below it; measured number outside the range, above it.
By their numbers in this assay, from the lowest: compounds 2 and 1 (each within the scatter of the next); then compound 3.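

In this assay, hydroxy in place of hydrogen on a saturated ring carbon, next to the ring atom that bears a large group, gives a 5.4-fold higher number from compound 1 to compound 3 (0.73 log units; beyond the scatter), a modest step towards weaker inhibition. The earlier fluoro step on an aromatic carbon stayed within the scatter, whereas this saturated ring carbon does respond to a single added group. Nothing available accounts for the step. Still open, on these data alone, is whether a methoxy group or an amine at this carbon would behave as hydroxy does. Also open, as far as these compounds go, is whether the other stereoisomers of compound 3 would give a similar number.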